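This account rests on a few compounds, and the source may have more. Where it says the series, first, only, none or still open, it means among the compounds named here.

Measured compounds in an ADME assay on HepG2 2.2.15 cells (Homo sapiens) for cytotoxicity; on this read-out lower numbers stand for higher toxicity in this test and higher numbers for lower toxicity in this test:

Compound 1 `O=C(Nc1ncc(Cc2ccc(F)cc2)s1)c1ccc(Cl)cc1Cl` gives > 50000 nM in this assay, which is a limit of the assay rather than a number.
Compound 2 `CC(C)(C)OC(=O)Nc1ncc(C(Oc2ccc(Br)cc2)c2ccc(Cl)cc2)s1` gives > 50000 nM in this assay, likewise a limit.
Compound 3 `CC(C)(C)OC(=O)Nc1ncc(C(Oc2ccc(OCc3ccccc3)cc2)c2ccc(Cl)cc2)s1` gives > 50000 nM in this assay, again a limit.

Where compound 2 stands: only a limit is known for it, and the two further values shown are limits as well, so no ordering among the three compounds can be read from this assay.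

Compound 4 `CC(C)(C)OC(=O)Nc1ncc(C(Oc2ccc3cc(Br)ccc3c2)c2ccc(Cl)cc2)s1` is not yet measured. It differs from compound 2 by 6-bromonaphthalen-2-yl in place of 4-bromophenyl on an oxygen on a saturated carbon, in words: 6-bromonaphthalen-2-yl in place of 4-bromophenyl on an oxygen on a saturated carbon.

For the measured compounds named here, the one measured step, a step that the two limits leave unreadable from compound 2 to compound 3, changes the group on the same aromatic ring, but both ends sit at the limit and its size cannot be read. Because (the limit of > 50000 nM in this assay, at which 3 of the 3 values shown sit), every value seen so far sits at the limit, and no step beyond the scatter has been observed in either direction.

The expected step from compound 2 to compound 4 is therefore a step that the limit leaves unreadable from compound 2 to compound 4, that is, no readable change. For compound 4 in this assay the estimate is 60000 nM, with a range from 20000 nM to 200000 nM, and the result is most likely to be reported again as a limit rather than a number.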

Compound 4, half-maximal cytotoxic concentration: > 50000 nM
Compound 4 ended at the assay's limit; the forecaster's own chance of this, stated with the estimate: 80%; the middle value does not contradict the limit.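

In this assay, for the compounds shown here, compound 2 and compound 4 both sit at a limit of the assay, so no step between them can be read. The compounds shown leave open at what concentration, if any, cytotoxicity appears, and whether 6-bromonaphthalen-2-yl in place of 4-bromophenyl alters it.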